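This account rests on a few compounds, and the source may have more. Where it says the series, first, only, none or still open, it means among the compounds named here.

Compound 2 `Cc1nn([C@H](C)c2ccc(Cl)cc2Cl)c2nc(N3CC[C@H](N4CCCCC4)[C@H](C)C3)cnc12` stands second highest among the three numbers measured in an assay on CCRF-CEM cells for antagonist activity at C-C chemokine receptor type 4 (Homo sapiens), read by CellTiter-Glo, with stated times of 30 min and 60 min, in the presence of a further agent that is not named here (on this read-out lower numbers stand for stronger inhibition and higher numbers for weaker inhibition), where compound 2 gives 361 nM. Its nearest neighbour is compound 1 `Cc1nn([C@H](C)c2ccc(Cl)cc2Cl)c2nc(N3CC[C@H](N4CCC4)[C@H](C)C3)cnc12`, which in this assay gives 218 nM; the only single-point step among these compounds, a 1.7-fold higher number from compound 1 to compound 2 (0.22 log units; within the scatter), is within the scatter. Furthest away is compound 3 `C[C@@H]1CC(c2cnc3c(C#N)nn([C@H](C)c4ccc(Cl)cc4Cl)c3n2)=CC[C@@H]1N1CCC[C@H]1C(C)(C)O`, which in this assay gives 1200 nM, a number beyond the scatter from compound 2, but compound 3 differs from compound 2 in more than one place, so no single step connects them.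

Compound 4 `Cc1nn([C@H](C)c2ccc(Cl)cc2Cl)c2nc(N3CC[C@H](N4CCC[C@H]4CO)[C@H](C)C3)cnc12` is not yet measured. It differs from compound 2 by 2-(hydroxymethyl)pyrrolidin-1-yl in place of piperidin-1-yl on a saturated ring carbon. Going by the values given here, the one measured step that bears on this position, a 1.7-fold higher number from compound 1 to compound 2 (0.22 log units; within the scatter), shows that exchanging one saturated nitrogen ring for another of a different size at this carbon moved the number within the scatter only. Among the compounds with values here, the entering group carries a hydroxymethyl substituent and one defined stereocentre, for which there is no measured single step at all; compound 3, with its own substituted five-membered ring, gives 1200 nM but on a different core. The step of a 1.1-fold higher number from compound 2 to compound 4 (0.04 log units; within the scatter) is therefore expected to stay within the scatter or be modest. Compound 4 is estimated at 400 nM, with a range from 150 nM to 1200 nM.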

Compound 4, half-maximal inhibitory concentration: 151 nM
Compound 4: middle estimate off by 2.6-fold (0.42 log units), on the high side, within the range that was stated.
By their numbers in this assay, from the lowest: compounds 4, 1 and 2 (each within the scatter of the next, the first and the last beyond it); then compound 3.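

In this assay the position on a saturated ring carbon, next to the ring atom that bears a methyl group, now shows a change beyond the scatter: a 2.4-fold lower number from compound 2 to compound 4 (0.38 log units; beyond the scatter). The earlier exchange of one saturated nitrogen ring for another, a 1.7-fold higher number from compound 1 to compound 2 (0.22 log units; within the scatter), did not show this, and the comparison with the smaller ring remains within the scatter: a 1.4-fold lower number from compound 1 to compound 4 (0.16 log units; within the scatter), so 2-(hydroxymethyl)pyrrolidin-1-yl is set apart from piperidin-1-yl but not from azetidin-1-yl. The change alters the ring size and brings in a hydroxymethyl substituent with one defined stereocentre in a single move, and nothing given here accounts for the step.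

The compounds shown leave open whether the step belongs to the five-membered ring or to the hydroxymethyl substituent, a question that an unsubstituted pyrrolidin-1-yl group, or a methoxymethyl group or a carboxylic acid in place of the hydroxymethyl, would address. Also open, going by these compounds, is what the opposite configuration at the defined stereocentre would give, and how this group would read on the core of compound 3, which gives 1200 nM but differs from compound 4 in more than one place.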